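Nitro in Place of Methyl: From Compound 3 to Compound 4

This account rests on a few compounds, and the source may have more. Where it says the series, first, only, none or still open, it means among the compounds named here.

Compound 1 `CCOC(=O)c1cccc(-c2ccc(C)cc2)c1` gives 140000 nM in an assay on COS-7 cells for inhibition of patatin-like phospholipase domain-containing protein 2 (Mus musculus); a higher number here means a weaker inhibitor, a lower number a stronger inhibitor.
Compound 2 `CCOC(=O)c1cccc(-c2ccc(C(C)N(C)C)cc2)c1` gives 200000 nM in this assay.
Compound 3 `CCOc1ccc(-c2cccc(C)c2)cc1` gives 70000 nM in this assay.

Compound 3 has the lowest of the three numbers; its gap to compound 1 lies within the scatter, its gap to compound 2 beyond it. Compound 4 `CCOc1ccc(-c2cccc([N+](=O)[O-])c2)cc1` differs from compound 3 by one change: nitro in place of methyl on an aromatic carbon. Within the data shown here, only one measured step exists, a 1.4-fold higher number from compound 1 to compound 2 (0.15 log units; within the scatter), and it concerns another group elsewhere in the structure, so nothing measured speaks directly to a nitro group. Without a bearing step, compound 4 is expected to stay close to compound 3, giving no change at the digits printed from compound 3 to compound 4 (within the scatter). Compound 4 is therefore estimated at 70000 nM, with a range from 25000 nM to 200000 nM.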

Compound 4, half-maximal inhibitory concentration: > 200000 nM
Compound 4 ended at the assay's limit; the forecaster's own chance of this, stated with the estimate: 20%; at least 2.8-fold (0.45 log units) between middle value and limit.
By their numbers in this assay, from the lowest: compounds 3, 1 and 2 (each within the scatter of the next, the first and the last beyond it).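

In this assay, nitro in place of methyl on this aromatic carbon gives an at least 2.8-fold higher number from compound 3 to compound 4 (0.45 log units; beyond the scatter), and unlike the earlier step, this one lies beyond the scatter. So the group on this carbon can matter, and here the change leads to a weaker inhibitor. Compound 4 reads > 200000 nM, which is a limit of the assay and not a number, so the step has a floor but no known size: the limit of > 200000 nM in this assay, at which 1 of the 4 values shown sits.

On these data alone, how far compound 4 really lies past that limit stays open. So does whether an amine or a carboxylic acid on this same carbon would give a lower number than methyl does.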